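Swapping the aryl on the ring nitrogen of compound 3

The compounds below may be only part of what the source reports. "The series", "measured", "known", "first", "only" and "open" are said of these compounds alone.

The measured compounds and their values in a functional assay on 143B cells (Homo sapiens) for inhibition, read by CCK-8 assay, with a stated time of 72 h, tested at 1 uM; on this read-out lower numbers stand for less inhibition and higher numbers for more inhibition at the one concentration tested (going by the name of the read-out):
compound 1, `COc1ccccc1N1C(=O)C(C)SC1c1cccc(C(=O)NCCCCc2ccccc2)c1`, 61%;
compound 2, `COc1ccccc1N1C(=O)CSC1c1cc(F)cc(C(=O)O)c1`, 0%;
compound 3, `COc1cccc(OC)c1N1C(=O)CSC1c1cccc(C(=O)NCCCCc2ccccc2)c1`, 31%.

Compound 3 stands second highest of the three numbers. Its nearest neighbour is compound 1, whose value lies higher by a margin beyond the scatter; its furthest is compound 2, whose value lies lower, again beyond the scatter. No pair among these three differs in only one place, so no single step is on record.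

Compound 4, `O=C(NCCCCc1ccccc1)c1cccc(C2SCC(=O)N2c2ccccc2F)c1`, is the unmeasured one. It differs from compound 3 as follows: 2-fluorophenyl in place of 2,6-dimethoxyphenyl on an amide-type nitrogen in a ring. For the measured compounds named here, the reduction of the group on that nitrogen to a smaller one without acceptors has no direct precedent here; compound 1 carries a different aryl together with a methyl on the ring, so it gives only a loose pointer toward higher inhibition. The step from compound 3 to compound 4 in this assay is therefore expected to be modest and upward, possibly within the scatter, a number 14 percentage points higher from compound 3 to compound 4 (beyond the scatter). Compound 4 is estimated at 45%, within a range of 15% to 75%.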

Compound 4, a percentage reported as inhibition, at one concentration (the size of the read-out at that concentration, not a potency): 59%
Estimate against measurement, compound 4: 14 percentage points below, within the range that was stated.
By their numbers in this assay, from the lowest: compound 2; then compound 3; then compounds 4 and 1 (each within the scatter of the next).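

In this assay, for the compounds shown here, with the rest of the molecule unchanged, replacing the 2,6-dimethoxyphenyl on the amide-type ring nitrogen by 2-fluorophenyl gives a number 28 percentage points higher from compound 3 to compound 4 (beyond the scatter) as the first single-place step in this set. This shows that the aryl group at this position can, on its own, shift inhibition by more than the usual scatter. The entering group has fewer heavy atoms and no hydrogen-bond acceptors, but nothing available here links either difference to the rise in inhibition.

The compounds shown leave open how an unsubstituted phenyl, a 2-chlorophenyl or a 2-methoxyphenyl would behave on this nitrogen with the rest of compound 4 kept. From the compounds shown here alone, it also remains open whether the same aryl swap would have a similar effect with a carboxylic acid in place of the amide side chain.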